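Methoxy Replaces Benzoyl: Cytotoxicity Expected to Stay Flat

A few compounds are considered here, and "the series" means these few. Any claim that something is new, unique, unknown or untested is made for them only; others in the source may bear on it.

Three measured compounds share one core and differ only in the group carried on one aromatic carbon. Compound 1 `O=C(Nc1cccc(-c2ccco2)c1)C1CCCN(C(=O)c2cc(C(F)(F)F)cc(C(F)(F)F)c2)C1` carries furan-2-yl there; compound 2 `CCc1cccc(NC(=O)C2CCCN(C(=O)c3cc(C(F)(F)F)cc(C(F)(F)F)c3)C2)c1` carries ethyl; compound 3 `O=C(c1ccccc1)c1cccc(NC(=O)C2CCCN(C(=O)c3cc(C(F)(F)F)cc(C(F)(F)F)c3)C2)c1` carries benzoyl. In an ADME assay on PC-3 cells (Homo sapiens) for cytotoxicity, read by WST assay, tested at 100 uM (a lower number here means less inhibition, a higher number more inhibition at the concentration tested (going by the name of the read-out)), compound 1 gives 0%, compound 2 gives 0% and compound 3 gives 0%. The steps between them are no change at the digits printed from compound 1 to compound 2 (within the scatter), no change at the digits printed from compound 1 to compound 3 (within the scatter) and no change at the digits printed from compound 2 to compound 3 (within the scatter), so compound 3 stands level with compounds 1 and 2 on the numbers shown.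

Compound 4 `COc1cccc(NC(=O)C2CCCN(C(=O)c3cc(C(F)(F)F)cc(C(F)(F)F)c3)C2)c1` is not yet measured. It differs from compound 3 as follows: methoxy in place of benzoyl on an aromatic carbon. Each of the three measured steps swapped one group on the same aromatic carbon and produced no change beyond the scatter, and the present change is of the same kind. The step of no change at the digits printed from compound 3 to compound 4 (within the scatter) is therefore expected to be no change beyond the scatter, in neither direction. Compound 4 is estimated to give 0%, with a range from 0% to 12%.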

Compound 4, a percentage reported as inhibition, at one concentration (the size of the read-out at that concentration, not a potency): 0%
Beside the measured number, compound 4's estimate shows no gap at the digits printed; low and high end bracket the measured number.
By their numbers in this assay, from the lowest: compounds 1, 2, 3 and 4 (each within the scatter of the next).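

Going from benzoyl, with 8 heavy atoms and a six-membered aromatic ring, to methoxy, with 2 heavy atoms and no ring, gives no change at the digits printed from compound 3 to compound 4 (within the scatter) in this assay, so at this aromatic carbon, meta to a large group, the reading holds with a much smaller group and without a ring in that group. Methoxy also attaches to the ring through oxygen, whereas furan-2-yl, ethyl and benzoyl all attach through carbon, and the comparisons with those groups read the same: no change at the digits printed from compound 2 to compound 4 (within the scatter) for methoxy in place of ethyl and no change at the digits printed from compound 1 to compound 4 (within the scatter) for methoxy in place of furan-2-yl. Nothing available accounts for this flat reading at the position.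

With compound 4 at 0% and its three comparators at the same printed value, these compounds do not show whether any group on this carbon can move the reading in this assay. An amine or a carboxylic acid at this position remains an open case, as does a change to the trifluoromethyl groups elsewhere on the shared core.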